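From 5-fluoropyridin-2-yl to 5-fluoropyridin-3-yl on a sulfonyl sulfur

A few compounds are considered here, and "the series" means these few. Any claim that something is new, unique, unknown or untested is made for them only; others in the source may bear on it.

Values in a physicochemical assay for lipophilicity, read by HPLC, at pH 7.4 (on this read-out lower numbers stand for lower lipophilicity and higher numbers for higher lipophilicity), are as follows:
- compound 1 `CNCc1cn(S(=O)(=O)c2ccoc2)c(-c2cccnc2F)c1F` gives 0.45
- compound 2 `CNCc1cn(S(=O)(=O)c2cccc(OC)n2)c(-c2cccnc2F)c1F` gives 1.03
- compound 3 `CNCc1cn(S(=O)(=O)c2ccc(F)cn2)c(-c2cccnc2F)c1F` gives 0.42

Compound 3 shares the low end of this small set with compound 1 and lies clearly under compound 2. Compound 4 `CNCc1cn(S(=O)(=O)c2cncc(F)c2)c(-c2cccnc2F)c1F` differs from compound 3 by 5-fluoropyridin-3-yl in place of 5-fluoropyridin-2-yl on a sulfonyl sulfur and so carries 5-fluoropyridin-3-yl in place of 5-fluoropyridin-2-yl on a sulfonyl sulfur. For the measured compounds named here, no measured step makes this exact swap. The nearest evidence is a number 0.03 log units lower from compound 1 to compound 3 (within the scatter) and a number 0.61 log units lower from compound 2 to compound 3 (beyond the scatter) where only the second, which removes a 6-methoxypyridin-2-yl, is beyond the scatter. The expected result is a number 0.08 log units higher from compound 3 to compound 4 (within the scatter) and thus no clear change in this assay here. Compound 4 is estimated at 0.5 with an expected range from 0.15 to 0.9 in this measurement.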

Compound 4, distribution coefficient: 0.83
For compound 4 the middle estimate is 0.33 log units below the measured one, and the stated range covers the measured number.
By their numbers in this assay, from the lowest: compounds 3 and 1 (each within the scatter of the next); then compounds 4 and 2 (each within the scatter of the next).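

Changing only how the same fluoropyridine is attached to a sulfonyl sulfur matters in this assay: 5-fluoropyridin-3-yl in place of 5-fluoropyridin-2-yl gives a number 0.41 log units higher from compound 3 to compound 4 (beyond the scatter). The same group gives a number 0.38 log units higher from compound 1 to compound 4 (beyond the scatter), so the parity of furan-3-yl and 5-fluoropyridin-2-yl does not extend to this isomer. It also gives a number 0.20 log units lower from compound 2 to compound 4 (within the scatter), so this place can reach the level of the 6-methoxypyridin-2-yl compound without a methoxy group.

Nothing shown accounts for the shift. Going by these compounds, how an unfluorinated pyridin-3-yl or a carboxylic acid on this ring would read remains open.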